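Bromo in Place of Hydrogen on a Flavone Benzoxazine

This account rests on a few compounds, and the source may have more. Where it says the series, first, only, none or still open, it means among the compounds named here.

Two flavones carrying a cyclic amine were tested. Compound 1 `Cc1cc(C)c2c(c1)CN(c1ccc3c(=O)cc(-c4ccccc4)oc3c1)CO2` is reported in a functional assay on MCF7 cells (Homo sapiens) for inhibition, read by MTT assay, with a stated time of 48 h, tested at 15 ug/mL (on this read-out higher numbers stand for more inhibition of growth at the one concentration tested and lower numbers for less inhibition of growth), as "not active" (no number reported), without a number. Compound 2 `O=c1cc(-c2ccccc2)oc2ccc(N3COc4ccccc4C3)cc12` gives 34% in this assay, the only number shown in this series. Compound 3 `O=c1cc(-c2ccccc2)oc2ccc(N3COc4c(Br)cccc4C3)cc12` differs from compound 2 by bromo in place of hydrogen on an aromatic carbon. Among the compounds with values here, no measured pair shows what such a change does here, so the step from compound 2 to compound 3 is expected to stay within the scatter, with no clear direction, at a number 1 percentage points higher from compound 2 to compound 3 (within the scatter). Compound 3 is estimated at 35%, ranging from 15% to 55%.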

Compound 3, percent growth inhibition at one concentration: 37.8%
Compound 3: middle estimate off by 2.8 percentage points, on the low side; low and high end bracket the measured number.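

In this assay, within the data shown here, bromo in place of hydrogen on an aromatic carbon gives a number 3.8 percentage points higher from compound 2 to compound 3 (within the scatter), the first measured step. Among these compounds, this position therefore accepts a bromo with no shift beyond the usual scatter, which no earlier pair could show. No measurement at hand speaks to the reason for this result.

As far as these compounds go, what a methoxy group, an amine or a carboxylic acid would do at this same position remains open. From the compounds shown here alone, it is also open whether bromo on another aromatic carbon of the shared core would give a similar step.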